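The source may report more compounds than this note shows. Statements on the series, on what has been measured and on what is new or still open speak of the compounds shown alone.

In an assay on isolated protein for inhibition of Indoleamine 2,3-dioxygenase 1 (Homo sapiens), read by spectrophotometry (on this read-out higher numbers stand for weaker inhibition and lower numbers for stronger inhibition), compound 1 `O/N=C(/Nc1ccc(F)c(F)c1)c1ccc2occc2c1` gives 22700 nM. For compound 2 `O/N=C(/Nc1ccc(Cl)c(F)c1)c1ccc2occc2c1` this assay reports only a limit, > 30000 nM, and not a number. The change between them is chloro in place of fluoro on an aromatic carbon, and it brought an at least 1.3-fold higher number from compound 1 to compound 2 (0.12 log units; that floor lies within the scatter); the step can only be read as a floor because of the limit of > 30000 nM in this assay, at which 1 of the 3 values shown sits.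

Compound 3 `COCc1cc2cc(/C(=N\O)Nc3cccc(F)c3)ccc2o1` gives 7100 nM in this assay, the lower of the two numbers, with compound 1 the nearest to it. How the core of compound 3 differs from the core of compound 1 is not broken down here.

Compound 4 `COCc1cc2cc(/C(=N\O)Nc3cccc(Cl)c3)ccc2o1` has not yet been measured. It differs from compound 3 by chloro in place of fluoro on an aromatic carbon. This is the same kind of change as that from compound 1 to compound 2, though the surroundings differ: there the chloro entered ortho to a fluoro group and para to a large group, here it enters meta to a large group.

Beside an at least 1.3-fold higher number from compound 1 to compound 2 (0.12 log units; that floor lies within the scatter), a step of about a 1.3-fold higher number from compound 3 to compound 4 (0.13 log units; within the scatter) is expected in this assay for compound 4, resting on that earlier step. Compound 4 is therefore estimated at 9500 nM, between 4000 nM and 25000 nM.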

Compound 4, half-maximal inhibitory concentration: 1000 nM
Compound 4: the middle estimate sits 9.5-fold (0.98 log units) above what was measured, outside the stated range (below it).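

In this assay, chloro in place of fluoro, here 3-fluorophenyl to 3-chlorophenyl, brought a 7.1-fold lower number from compound 3 to compound 4 (0.85 log units; beyond the scatter). The change therefore did not carry over from one core to the other with a single size or direction: the same change on two cores in this assay, an at least 1.3-fold higher number (0.12 log units; that floor lies within the scatter) from compound 1 to compound 2 and a 7.1-fold lower number (0.85 log units; beyond the scatter) from compound 3 to compound 4, at least 9.3-fold (0.97 log units) apart, beyond the scatter of two such steps. This does not show which difference between the two pairs accounts for the gap, whether the core or the rest of the aromatic ring carrying the change, and compound 2 gives a limit and not a number: the limit of > 30000 nM in this assay, at which 1 of the 4 values shown sits.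

The compounds shown leave open whether a bromo or a methyl group in the same place on the core of compound 4 would continue the drop seen with chloro, or whether the gain is specific to chloro. They also leave open how the same exchange of fluoro for chloro would read on a third core, so no general rule for this series can be drawn from two pairs.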